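The source may hold more compounds than are shown below. What is called first, only, known or untested is meant among the compounds shown, and "the series" means these compounds.

Compound 1, with the structure `CCOC(=O)[C@@H]1CCC[C@H](S(=O)(=O)c2ccc(S(=O)(=O)N(CC)CC)cc2)C1`, sits at the weak end of a small set tested in a functional assay on BXPC-3 cells (Homo sapiens) for inhibition, read by MTT assay, with a stated time of 7 days; a higher number here means a weaker inhibitor, a lower number a stronger inhibitor. Compound 1 gives 25200 nM. Compound 2, `CCOC(=O)C1CCN(S(=O)(=O)c2ccc(S(=O)(=O)N(CC)CC)cc2)CC1`, gives 23100 nM, and the two values lie within the scatter of each other, so no order can be read between them. Compound 3, `CC(C)c1noc(N2CCN(C(=O)[C@@H]3CCCN(S(=O)(=O)c4ccc(S(=O)(=O)NC(C)(C)C)cc4)C3)CC2)n1`, gives 2600 nM, which lies beyond the scatter on the stronger side of compound 1.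

Compound 4, `CCOC(=O)[C@@H]1CCC[C@@H](S(=O)(=O)c2ccc(S(=O)(=O)N(CC)CC)cc2)C1`, differs from compound 1 only in configuration: the two compounds have the same atoms and bonds and differ only in configuration as drawn: 1 of 2 stereo elements differ; a stereocentre at a saturated ring carbon is drawn S in compound 1 and R in compound 4. Going by the values given here, no pair of measured compounds that differs in one place exists to guide the step. With nothing to point either way, the step from compound 1 to compound 4 is expected to be none beyond the scatter, written as a 1.0-fold lower number from compound 1 to compound 4 (0.00 log units; within the scatter). Compound 4 is therefore estimated to give 25000 nM, between 8000 nM and 70000 nM.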

Compound 4, half-maximal inhibitory concentration: 18500 nM
Estimate against measurement, compound 4: 1.4-fold (0.13 log units) above; measured number inside the range.
By their numbers in this assay, from the lowest: compound 3; then compounds 4, 2 and 1 (each within the scatter of the next).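

Going by these compounds alone, compound 1 and compound 4 form the first pair in this set that differs in one place, and in this assay the step is a 1.4-fold lower number from compound 1 to compound 4 (0.13 log units; within the scatter). Changing this stereocentre at a saturated ring carbon from S to R therefore shows no preference for either configuration. The comparison isolates that single change: the fact that compounds 1 and 4 differ only in the configuration as drawn.

The compounds shown leave open whether configuration here would matter with a carboxylic acid in place of the ethyl ester. They also leave open what changing the second stereocentre would do.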